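The source may hold more compounds than are shown below. What is called first, only, known or untested is meant among the compounds shown, and "the series" means these compounds.

Measured compounds:
Compound 1, `COc1cc(OC)c(-c2coc3cc(OCC(=O)c4cccc(C(F)(F)F)c4)ccc3c2=O)cc1OC`: in a functional assay on U-251 cells (Homo sapiens) for antiproliferative activity, read by MTT assay, with a stated time of 24 h (a lower number here means a stronger inhibitor, a higher number a weaker inhibitor), compound 1 gives > 10000 nM, which is a limit of the assay rather than a number.
Compound 2, `COc1cc(OC)c(-c2coc3cc(OCc4ccccc4F)ccc3c2=O)cc1OC`: in this assay compound 2 gives 2890 nM.
Compound 3, `COc1cc(OC)c(-c2coc3cc(OCc4ccccc4C)ccc3c2=O)cc1OC`: in this assay compound 3 gives 2000 nM.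

Of the two plain numbers, compound 2 has the higher one, but the gap to compound 3, a 1.4-fold lower number from compound 2 to compound 3 (0.16 log units; within the scatter), lies within the scatter, so the two cannot be ranked against each other. Compound 1 sits at the limit of > 10000 nM in this assay, at which 1 of the 3 values shown sits.

Compound 4, `COc1cc(OC)c(-c2coc3cc(OCc4ccc(Cl)cc4)ccc3c2=O)cc1OC`, differs from compound 2 in one place: 4-chlorophenyl in place of 2-fluorophenyl on a saturated chain carbon bound to an oxygen on an aromatic ring.

Among the measured compounds shown here, three measured steps touch this part of the molecule. an at least 3.4-fold lower number from compound 1 to compound 2 (0.53 log units; beyond the scatter) and an at least 5.0-fold lower number from compound 1 to compound 3 (0.69 log units; beyond the scatter) show that exchanging the (3-(trifluoromethyl)phenyl)carbonyl for 2-fluorophenyl or 2-methylphenyl lowers the number at least modestly. a 1.4-fold lower number from compound 2 to compound 3 (0.16 log units; within the scatter) shows that trading fluoro for methyl on that ring changes nothing beyond the scatter. For the measured compounds named here, no measured step compares 4-chlorophenyl with any of these groups, so the direction of the change is not given by the data. The step from compound 2 to compound 4 is therefore expected to stay within the scatter: a 1.2-fold lower number from compound 2 to compound 4 (0.06 log units; within the scatter). Compound 4 is estimated at 2500 nM, with a range from 900 nM to 7000 nM.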

Compound 4, half-maximal inhibitory concentration: 470 nM
Estimate against measurement, compound 4: 5.3-fold (0.73 log units) above; measured number below the stated range.
By their numbers in this assay, from the lowest: compound 4; then compounds 3 and 2 (each within the scatter of the next). At a limit, above all of these: compound 1.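

Among the benzyl groups on this oxygen, the only earlier comparison, a 1.4-fold lower number from compound 2 to compound 3 (0.16 log units; within the scatter), stayed within the scatter, so it gave no sign that the choice of ring substituent mattered in this assay. The new result shows that it can matter, with a 6.1-fold lower number from compound 2 to compound 4 (0.79 log units; beyond the scatter) and a 4.3-fold lower number from compound 3 to compound 4 (0.63 log units; beyond the scatter), both beyond the scatter, which makes compound 4, carrying 4-chlorophenyl, the strongest inhibitor of the four. The step away from the (3-(trifluoromethyl)phenyl)carbonyl group is also the largest seen here, an at least 21-fold lower number from compound 1 to compound 4 (1.32 log units; beyond the scatter), but its true size stays unknown because compound 1 gives only a limit of the assay: the limit of > 10000 nM in this assay, at which 1 of the 4 values shown sits.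

The step from 2-fluorophenyl to 4-chlorophenyl changes both the atom on the ring and its place, so these compounds cannot say which of the two goes with the lower number; 4-fluorophenyl and 2-chlorophenyl groups on the same carbon would separate them. Also open, from the compounds shown here alone, is how an unsubstituted phenyl ring, or a ring carrying an amine or a carboxylic acid, would read at this position.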